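Notes on a methoxy to dimethylamino exchange

The compounds below may be only part of what the source reports. "The series", "measured", "known", "first", "only" and "open" are said of these compounds alone.

Measured so far in a functional assay on PC-3 cells (Homo sapiens) for inhibition, read by MTT assay, with a stated time of 48 h; a higher number here means a weaker inhibitor, a lower number a stronger inhibitor:
compound 1 `COc1ccc(-n2c(SCc3ccc(C)cc3)nnc2-c2cc(OC)c(OC)c(OC)c2)cc1`, 56500 nM
compound 2 `COc1ccc(-n2c(SCC(=O)c3ccc4ccccc4c3)nnc2-c2cc(OC)c(OC)c(OC)c2)cc1`, > 60000 nM
compound 3 `COc1ccc(-n2c(SCC(=O)Nc3ccc(Cl)cc3)nnc2-c2cc(OC)c(OC)c(OC)c2)cc1`, 6290 nM

Compound 2 stands at a limit of this assay rather than at a number, the value > 60000 nM being the cut-off at which one of the three results sits (the limit of > 60000 nM in this assay, at which 1 of the 3 values shown sits). For the measured compounds named here, compound 1 gives a numerical value close to that cut-off, and compound 3 is the only member clearly inside the measured range.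

The measured steps all alter the group on the saturated chain carbon bound to a sulfur: an at least 1.0-fold higher number from compound 1 to compound 2 (0.02 log units; that floor lies within the scatter); a 9.0-fold lower number from compound 1 to compound 3 (0.95 log units; beyond the scatter); an at least 9.5-fold lower number from compound 2 to compound 3 (0.97 log units; beyond the scatter). The first of these is a floor within the scatter; the other two are modest and beyond it.

Compound 4 `COc1cc(-c2nnc(SCC(=O)c3ccc4ccccc4c3)n2-c2ccc(N(C)C)cc2)cc(OC)c1OC` differs from compound 2 elsewhere: dimethylamino in place of methoxy on an aromatic carbon. Going by the values given here, no measured step touches this six-membered aromatic ring, so none of the steps above bears directly on the change from compound 2 to compound 4. Among the compounds with values here, with compound 2 at the limit and no precedent for this exchange, the expected step is one within the scatter, a step that the limit leaves unreadable from compound 2 to compound 4. Compound 4 is therefore estimated at 70000 nM in this assay, with a range from 25000 nM to 200000 nM, and a result reported only as a limit is judged likely.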

Compound 4, half-maximal inhibitory concentration: 18100 nM
Estimate against measurement, compound 4: 3.9-fold (0.59 log units) above, outside the stated range (below it).
By their numbers in this assay, from the lowest: compound 3; then compound 4; then compound 1. At a limit, above all of these: compound 2.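

In this assay, dimethylamino in place of methoxy gives an at least 3.3-fold lower number from compound 2 to compound 4 (0.52 log units; beyond the scatter), the only step shown on the six-membered aromatic ring of carbon only, at the aromatic carbon para to a large group. The earlier steps shown here all altered the group on the saturated chain carbon bound to a sulfur, whereas this result shows that the 4-methoxyphenyl to 4-(dimethylamino)phenyl change alone, with the naphthalen-2-yl carbonyl side chain kept, is enough to bring the series to a numerical reading, with compound 4 at 18100 nM. Compound 2 stands at a limit, so the step is a floor and its full size cannot be read: the limit of > 60000 nM in this assay, at which 1 of the 4 values shown sits.

The compounds shown leave open whether the same exchange would give a similar step with the (4-chlorophenyl)carbamoyl side chain of compound 3 or the 4-methylphenyl group of compound 1. They also leave open how a primary amine, a diethylamino group or a pyrrolidin-1-yl ring would compare with dimethylamino at this aromatic carbon, and so whether the step depends on the amine nitrogen or on its two methyl groups.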